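From dimethylamino to hydroxy: what compound 4 may show

The compounds below may be only part of what the source reports. "The series", "measured", "known", "first", "only" and "open" are said of these compounds alone.

In a functional assay on HOP-62 cells (Homo sapiens) for inhibition, read by sulforhodamine B assay (on this read-out higher numbers stand for weaker inhibition of growth and lower numbers for stronger inhibition of growth), compound 1 (`Cc1ccc2[nH]c(-c3ccc(-c4ccc(-c5ccc(N(C)C)cc5)cc4)cc3)nc2c1`) gives 4230 nM and compound 3 (`CN(C)c1ccc(-c2ccc(-c3ccc(-c4nc5c(O)cccc5[nH]4)cc3)cc2)cc1`) gives 8250 nM on the same scale. Those two stand within the scatter of each other, while compound 2 (`COc1ccc(-c2ccc(-c3ccc(-c4nc5ccccc5[nH]4)cc3)cc2)cc1`) gives 100000 nM as a much higher number. Compound 4 (`Cc1ccc2[nH]c(-c3ccc(-c4ccc(-c5ccc(O)cc5)cc4)cc3)nc2c1`) keeps the core of compound 1 and carries hydroxy in place of dimethylamino on an aromatic carbon, para to a large group (hydroxy in place of dimethylamino on an aromatic carbon). Among the measured compounds shown here, the only measured step (a 2.0-fold higher number from compound 1 to compound 3 (0.29 log units; within the scatter)) replaces 5-methyl-1H-benzimidazol-2-yl and leaves dimethylamino untouched, so it does not test this change. For the measured compounds named here, compound 2 is the only measured compound without dimethylamino, yet it also differs from compound 1 in a second place, which makes it a loose guide. Even so, compound 2 with 100000 nM points upward, and no measured compound argues for a drop. The expected step is a 4.7-fold higher number from compound 1 to compound 4 (0.67 log units; beyond the scatter) in this assay towards weaker inhibition of growth. Compound 4 is estimated at 20000 nM with an expected range from 5000 nM to 100000 nM in this read-out.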

Compound 4, concentration for 50% growth inhibition: 41200 nM
Compound 4: the middle estimate sits 2.1-fold (0.31 log units) below what was measured; measured number inside the range.
By their numbers in this assay, from the lowest: compounds 1 and 3 (each within the scatter of the next); then compound 4; then compound 2.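

In this assay, among the compounds shown here, the step of a 9.7-fold higher number from compound 1 to compound 4 (0.99 log units; beyond the scatter) is the first direct reading of the group on an aromatic carbon para to a large group, since the earlier step, a 2.0-fold higher number from compound 1 to compound 3 (0.29 log units; within the scatter), left dimethylamino in place. It shows that this position is not indifferent: with the rest of compound 1 unchanged, replacing dimethylamino with hydroxy moves the number beyond the scatter, towards weaker inhibition of growth. Nothing available here accounts for the size of this step, and it rests on a single pair of compounds.

From the compounds shown here alone, whether a plain amino group or a carboxylic acid at this position would stay nearer to compound 1 or to compound 4 remains open. So does whether the same exchange would give a similar step on the core of compound 3.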